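The source may report more compounds than this note shows. Statements on the series, on what has been measured and on what is new or still open speak of the compounds shown alone.

Measured compounds:
- compound 1, `O=C(Nc1cccc(-n2cc(-c3ccncc3)c(-c3ccc(Cl)c(O)c3)n2)c1)Nc1ccc(Cl)c(Cl)c1`: 1500 nM
- compound 2, `COc1cc(-c2nn(-c3cccc(NC(=O)c4cccc(C(F)(F)F)c4)c3)cc2-c2ccncc2)ccc1Cl`: 1760 nM
- compound 3, `COc1cc(-c2nn(-c3cccc(NC(=O)Nc4ccc(Cl)c(C(F)(F)F)c4)c3)cc2-c2ccncc2)ccc1Cl`: 1500 nM

In a functional assay on DU-145 cells (Homo sapiens) for inhibition, read by sulforhodamine B assay, with a stated time of 48 h (on this read-out higher numbers stand for weaker inhibition of growth and lower numbers for stronger inhibition of growth), compound 2 gives the highest of the three numbers, yet its nearest neighbour compound 1 and its furthest neighbour compound 3 both sit within the scatter of it, so no order among the three can be read. Among the measured compounds shown here, the one step measured in one place, a 1.2-fold lower number from compound 2 to compound 3 (0.07 log units; within the scatter), swaps the whole aryl on the carbonyl carbon for an arylamino and still stays flat.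

Compound 4, `COc1cc(-c2nn(-c3cccc(NC(=O)c4ccccc4)c3)cc2-c2ccncc2)ccc1Cl`, is not yet measured. It differs from compound 2 in one place: hydrogen in place of trifluoromethyl on an aromatic carbon. For the measured compounds named here, the change sits on the same aryl that the step from compound 2 to compound 3 replaced altogether without moving the number, and no measured step addresses the trifluoromethyl on its own. The series therefore gives no ground to expect more than a flat step in this assay; the estimate leans only slightly toward a weaker number because a 1.2-fold lower number from compound 2 to compound 3 (0.07 log units; within the scatter) shows this part of the molecule tolerating change in either direction within the scatter.

Compound 4 is expected to give 2200 nM, between 900 nM and 5500 nM. The step this implies, a 1.3-fold higher number from compound 2 to compound 4 (0.10 log units; within the scatter), is estimated to stay inside the scatter.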

Compound 4, concentration for 50% growth inhibition: 780 nM
Compound 4: middle estimate off by 2.8-fold (0.45 log units), on the high side, and the stated range ends above it.
By their numbers in this assay, from the lowest: compounds 4, 1, 3 and 2 (each within the scatter of the next, the first and the last beyond it).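

In this assay, among the compounds shown here, hydrogen in place of trifluoromethyl on an aromatic carbon gives a 2.3-fold lower number from compound 2 to compound 4 (0.35 log units; beyond the scatter), the first step beyond the scatter. This aryl is therefore less indifferent to change than the flat step, a 1.2-fold lower number from compound 2 to compound 3 (0.07 log units; within the scatter), alone suggested, and the trifluoromethyl at this carbon is not needed for the growth inhibition seen here. Phenyl in place of (4-chloro-3-(trifluoromethyl)phenyl)amino on a carbonyl carbon gives a 1.9-fold lower number from compound 3 to compound 4 (0.28 log units; within the scatter), which stays within the scatter, so the gain from removing the group is established only against compound 2. No evidence on the origin of the step from trifluoromethyl to hydrogen is available.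

On these data alone, it remains open whether this step reflects the trifluoromethyl specifically or any group on this carbon; a methyl, an amine or a carboxylic acid there would separate those two readings. As far as these compounds go, it also remains open whether the same exchange of trifluoromethyl for hydrogen would carry over to the arylamino carbonyl of compound 3, where a chlorine is also present on the aryl.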